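Homologating the hydroxy side chain in a tetrazole amide series

A few compounds are considered here, and "the series" means these few. Any claim that something is new, unique, unknown or untested is made for them only; others in the source may bear on it.

Compounds measured so far:
compound 1, `Cc1cccc([C@@H](O)C(=O)N2N=CC[C@H]2C(=O)NCc2cc(Cl)ccc2-n2cnnn2)c1`, < 12 mL.min-1.g-1
compound 2, `O=C(NCc1cc(Cl)ccc1-n1cnnn1)[C@@H]1CC=NN1C(=O)[C@H](O)c1ccccc1`, < 12 mL.min-1.g-1

Compound 2 is `O=C(NCc1cc(Cl)ccc1-n1cnnn1)[C@@H]1CC=NN1C(=O)[C@H](O)c1ccccc1`. In an ADME assay on liver for metabolic stability, with Liver microsome (Homo sapiens) as the target, read by LC-MS, using microsomes (on this read-out higher numbers stand for fast clearance and lower numbers for slow clearance), compound 2 gives < 12 mL.min-1.g-1, which is a limit of the assay and not a number. Compound 1, `Cc1cccc([C@@H](O)C(=O)N2N=CC[C@H]2C(=O)NCc2cc(Cl)ccc2-n2cnnn2)c1`, also gives a limit in this assay, < 12 mL.min-1.g-1. Among the compounds with values here, the only measured step, a step that the two limits leave unreadable from compound 1 to compound 2, is therefore unreadable in size, and both values sit at the limit of < 12 mL.min-1.g-1 in this assay, at which 2 of the 2 values shown sit.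

Compound 3 is `O=C(NCc1cc(Cl)ccc1-n1cnnn1)[C@@H]1CC=NN1C(=O)[C@H](O)Cc1ccccc1`. It differs from compound 2 by benzyl in place of phenyl on a saturated chain carbon bound to a carbonyl carbon and an oxygen on a saturated carbon. Within the data shown here, no measured step touches this change, so there is no basis for expecting a step in this assay beyond the scatter in either direction. Given that compound 2 sits at a limit, compound 3 is expected to stay near it, with a step that the limit leaves unreadable from compound 2 to compound 3 as the expected step. The estimate for compound 3 is 10 mL.min-1.g-1, within 4 mL.min-1.g-1 to 25 mL.min-1.g-1.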

Compound 3, intrinsic clearance in microsomes: < 12 mL.min-1.g-1
Compound 3: a limit, no number; the forecaster's own chance of this, stated with the estimate: 60%; the middle value is on the limit's open side.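

Compound 3, like compound 1 and compound 2, gives only a limit and not a number, so no step among these compounds can be read: the limit of < 12 mL.min-1.g-1 in this assay, at which 3 of the 3 values shown sit. The compounds shown leave open whether benzyl in place of phenyl changes clearance at all.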